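This account rests on a few compounds, and the source may have more. Where it says the series, first, only, none or still open, it means among the compounds named here.

Series notes, step from compound 3 to compound 4.

Among the compounds with values here, compound 3 `CC(C)(C)OC(=O)NCCCC[C@H](NC(=O)CN(c1ncnc2c1ncn2C1CCCCO1)C1CC1)C(=O)OCc1ccccc1` stands highest of the three numbers so far in a functional assay on the whole organism (Tail, strain ICR) with Mus musculus as the target, in the tail flick test, with a stated time of 120 min, at a dose of 25 umol/kg by the oral route (on this read-out lower numbers stand for a weaker effect and higher numbers for a stronger effect at the one dose given), where compound 3 gives 28.4%. Its nearest neighbour is compound 1 `O=C(CN(c1ncnc2c1ncn2C1CCCCO1)C1CC1)N[C@@H](CCC(=O)OCc1ccccc1)C(=O)OCc1ccccc1`; in this assay compound 1 gives 20.7%, and the step of a number 7.7 percentage points higher from compound 1 to compound 3 (within the scatter) stays within the scatter. The furthest is compound 2 `O=C(CN(c1ncnc2c1ncn2C1CCCCO1)C1CC1)NCC(=O)OCc1ccccc1`; in this assay compound 2 gives 17.2%, and the step of a number 11.2 percentage points higher from compound 2 to compound 3 (beyond the scatter) is the only one beyond the scatter. Between the two smaller compounds the step of a number 3.5 percentage points lower from compound 1 to compound 2 (within the scatter) is within the scatter.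

Compound 4 `CC(C)[C@H](NC(=O)CN(c1ncnc2c1ncn2C1CCCCO1)C1CC1)C(=O)OCc1ccccc1` differs from compound 3 by isopropyl in place of 4-((tert-butoxycarbonyl)amino)butyl on a saturated chain carbon bound to an amide-type nitrogen and a carbonyl carbon. Within the data shown here, the step that bears on it most is the one from compound 2 to compound 3, where the 4-((tert-butoxycarbonyl)amino)butyl group entered and the number rose by a modest amount; compound 4 gives up that group again, keeping only isopropyl at the same place. The step from compound 1 to compound 3 also bears on it, and was within the scatter. The expected step of a number 8.4 percentage points lower from compound 3 to compound 4 (within the scatter) therefore points downward, toward the region of compound 1 and compound 2, but is not expected to exceed the scatter clearly. Compound 4 is estimated at 20%, with a range from 10% to 30%.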

Compound 4, a percentage reported as activity, at one dose (the size of the read-out at that dose, not a potency): 25.8%
Estimate against measurement, compound 4: 5.8 percentage points below; measured number inside the range.
By their numbers in this assay, from the lowest: compounds 2, 1, 4 and 3 (each within the scatter of the next, the first and the last beyond it).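

With a number 2.6 percentage points lower from compound 3 to compound 4 (within the scatter) in this assay, isopropyl, with 3 heavy atoms and no hydrogen-bond donor or acceptor, gives a number within the scatter of that given by the 12-heavy-atom 4-((tert-butoxycarbonyl)amino)butyl group at this saturated chain carbon, so the larger group is not required to hold the number. The only gap beyond the scatter so far, between the hydrogen of compound 2 and the group of compound 3, now has compound 4 inside it, with a number 8.6 percentage points higher from compound 2 to compound 4 (within the scatter) and a number 5.1 percentage points higher from compound 1 to compound 4 (within the scatter) both also within the scatter, so isopropyl cannot be separated from any of the other three substituents at this place. No measurement is available that explains these results.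

The compounds shown leave open whether a 4-aminobutyl group or a carboxylic acid side chain at this place would move the number beyond the scatter. All numbers come from a single dose and time, so they leave relative potency open.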